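The source may hold more compounds than are shown below. What is called first, only, known or untested is meant among the compounds shown, and "the series" means these compounds.

Of the compounds shown here, three have so far been tested in a functional assay for inhibition, with Homo sapiens as the target; on this read-out lower numbers stand for an effect already at smaller amounts and higher numbers for an effect only at larger amounts of compound. Compound 1 `CN1N=C(c2ccc(N)cc2)CCC1=O` carries a free amino group on its aromatic ring. In this assay compound 1 reaches only > 46.4 ug/mL, which is a limit of the assay and not a number. Compound 2 `CC(=O)Nc1ccc(C2=NN(C)C(=O)CC2)cc1` differs from compound 1 in one place: acetyl in place of hydrogen on a nitrogen on an aromatic ring. In this assay compound 2 likewise gives only > 46.4 ug/mL, again a limit rather than a number. The step that the two limits leave unreadable from compound 1 to compound 2 therefore cannot be sized, since both ends sit at the limit of > 46.4 ug/mL in this assay, at which 2 of the 3 values shown sit. Compound 3 `CC1CC(c2ccc(N)cc2)=NNC1=O` is built from the same atoms as compound 1 joined differently; the difference between the two cores is not broken down here. In this assay, for the measured compounds named here, compound 3 gives 43.8 ug/mL, the only plain number among the three. Compound 4 `CC(=O)Nc1ccc(C2=NNC(=O)C(C)C2)cc1` is not yet measured; it stands to compound 3 as compound 2 stands to compound 1: acetyl in place of hydrogen on a nitrogen on an aromatic ring, the same kind of change at a place described in the same words. Because the earlier step that the two limits leave unreadable from compound 1 to compound 2 is not readable, and because compound 3 sits close to the limit of > 46.4 ug/mL in this assay, at which 2 of the 3 values shown sit, compound 4 is expected at 55 ug/mL, with a good chance that only a limit is reported. The step that this estimate means is expected to be a 1.3-fold higher number from compound 3 to compound 4 (0.10 log units; within the scatter).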

Compound 4, half-maximal effective concentration: 46.4 ug/mL
Estimate against measurement, compound 4: 1.2-fold (0.07 log units) above; the range from low to high includes it.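

In this assay, acetyl in place of hydrogen on a nitrogen on an aromatic ring gives a 1.1-fold higher number from compound 3 to compound 4 (0.03 log units; within the scatter), so compound 3 and compound 4 cannot be told apart on this read-out. On the core of compound 1, the same change gives a step that cannot be read, as compound 1 and compound 2 each give only a limit of the assay and not a number: the limit of > 46.4 ug/mL in this assay, at which 2 of the 4 values shown sit. The change can therefore be followed on one core only, which shows that the amino to acetamido swap makes no clear difference there but does not show that it would behave in the same way on the core of compound 1.

The compounds shown leave open whether a longer chain on that nitrogen, such as butanoyl in place of acetyl, would stand clearly apart from compound 3. They also leave open what a carboxylic acid in place of the amino group would give on either core.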